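Replacing Methoxy with Fluoro in Compound 3

The source may report more compounds than this note shows. Statements on the series, on what has been measured and on what is new or still open speak of the compounds shown alone.

Of the compounds shown here, three have been measured in a functional assay on A-375 cells (Homo sapiens) for antiproliferative activity, read by MTT assay, with a stated time of 72 h; on this read-out higher numbers stand for weaker inhibition and lower numbers for stronger inhibition. Compound 3 `COc1ccc(N2C(=O)COc3ccc(-c4cnc(Cl)c(NS(=O)(=O)c5ccc(F)cc5)c4)cc32)cc1` gives 32700 nM. Compound 2 `COc1ncc(-c2ccc3c(c2)NC(=O)CO3)cc1NS(=O)(=O)c1ccc(F)cc1` gives 26300 nM, and these two values lie within the scatter of each other, so neither can be placed ahead of the other. Compound 1 `COc1ccc(N2C(=O)COc3ccc(-c4ccc(O)cc4)cc32)cc1` reaches only a limit of the assay, > 40000 nM. That makes compound 3 one of just two compounds with a true number, and neither number indicates strong inhibition.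

The next compound, compound 4 `O=C1COc2ccc(-c3cnc(Cl)c(NS(=O)(=O)c4ccc(F)cc4)c3)cc2N1c1ccc(F)cc1`, keeps the framework of compound 3 and changes a single substituent. It carries fluoro in place of methoxy on an aromatic carbon, para to a large group, turning 4-methoxyphenyl into 4-fluorophenyl (fluoro in place of methoxy on an aromatic carbon).

Going by the values given here, no measured pair in this set differs in one place only, so no direct precedent exists for this change. The expectation therefore rests on compound 3 at 32700 nM and on compound 2 at 26300 nM, which sit close together. The expected change, a 1.2-fold lower number from compound 3 to compound 4 (0.07 log units; within the scatter), stays within the scatter, with no clear direction. For compound 4 the estimated value in this assay is 28000 nM, with an expected range from 11000 nM to 60000 nM.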

Compound 4, half-maximal inhibitory concentration: > 40000 nM
Compound 4 ended at the assay's limit; the forecaster's own chance of this, stated with the estimate: 35%; middle value at least 1.4-fold (0.15 log units) from the limit.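

Going by these compounds alone, the step from methoxy to fluoro is the first change in this set confined to a single place, on an aromatic carbon para to a large group, and it reads as an at least 1.2-fold higher number from compound 3 to compound 4 (0.08 log units; that floor lies within the scatter). Because that figure is only a floor, the step gives no true size, but it offers no sign that fluoro at this position brings stronger inhibition than methoxy in this assay. With compound 4 joining compound 1 at the limit, this result cannot be placed more precisely, and the upper end of the step stays undefined for the following reason: the limit of > 40000 nM in this assay, at which 2 of the 4 values shown sit.

The compounds shown leave open how far the number for compound 4 actually lies from that of compound 3, and whether this position matters much at all, since only one change at this place can be read and its floor lies within the scatter. Whether another group on this aromatic carbon, such as a dimethylamino group, a carboxylic acid or a plain hydrogen, would give a number clearly lower than that of compound 3 also remains unanswered.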